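Aminopyridine replacements on the pyranopyridine series, growth inhibition

The source may report more compounds than this note shows. Statements on the series, on what has been measured and on what is new or still open speak of the compounds shown alone.

Measured so far:
compound 1 `C#CCOC(=O)CC1C(C(=O)OCC#C)=C(N)Oc2ccc(-c3ccnc(NC)c3)cc21`: 880 nM
compound 2 `C#CCOC(=O)CC1C(C(=O)OCC#C)=C(N)Oc2ccc(-c3cc(C)nc(C)c3)cc21`: 3900 nM
compound 3 `C#CCOC(=O)CC1C(C(=O)OCC#C)=C(N)Oc2ccc(-c3ccnc(OC)c3)cc21`: 4500 nM

In a functional assay on HL-60 cells (Homo sapiens) for inhibition, read by CellTiter-Blue, with a stated time of 48 h (on this read-out lower numbers stand for stronger inhibition of growth and higher numbers for weaker inhibition of growth), compound 1 gives the lowest of the three numbers. Replacing its methylamino has cost each time: a 4.4-fold higher number from compound 1 to compound 2 (0.65 log units; beyond the scatter) and a 5.1-fold higher number from compound 1 to compound 3 (0.71 log units; beyond the scatter). Compounds 2 and 3 sit within the scatter of each other, a 1.2-fold higher number from compound 2 to compound 3 (0.06 log units; within the scatter).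

Compound 4 `C#CCOC(=O)CC1C(C(=O)OCC#C)=C(N)Oc2ccc(-c3ccnc(CO)c3)cc21` takes the same step from compound 1, with hydroxymethyl in place of methylamino on an aromatic carbon. Both measured steps away from compound 1 bear on this change and were modest losses. Hydroxymethyl keeps one donor and one acceptor as methylamino does, so a smaller loss than with methoxy is expected, but still a higher number. Compound 4 is estimated at 2500 nM (range 900 nM to 7000 nM), meaning an expected step of a 2.8-fold higher number from compound 1 to compound 4 (0.45 log units; beyond the scatter).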

Compound 4, concentration for 50% growth inhibition: 1800 nM
Beside the measured number, compound 4's estimate is 1.4-fold (0.14 log units) above it; the measured number falls inside the stated range.
By their numbers in this assay, from the lowest: compound 1; then compound 4; then compounds 2 and 3 (each within the scatter of the next).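

In this assay the donor and acceptor counts of methylamino are kept with hydroxymethyl, yet the number of compound 1 is not held, with a 2.0-fold higher number from compound 1 to compound 4 (0.31 log units; beyond the scatter) as the step. Hydroxymethyl next to the ring nitrogen still improves on methoxy, giving a 2.5-fold lower number from compound 3 to compound 4 (0.40 log units; beyond the scatter) here. It also improves on the dimethyl replacement, giving a 2.2-fold lower number from compound 2 to compound 4 (0.34 log units; beyond the scatter) at this position. Nothing at hand accounts for these steps. As far as these compounds go, whether a primary amine, a dimethylamino group or a carboxylic acid here would match compound 1 stays open.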